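The compounds below may be only part of what the source reports. "The series", "measured", "known", "first", "only" and "open" are said of these compounds alone.

Compound 1 `CCCNC(=O)NS(=O)(=O)c1ccc(-n2nc(-c3ccccc3)ccc2=O)cc1`: 77.2%
Compound 2 `CCCCNC(=O)NS(=O)(=O)c1ccc(-n2nc(-c3ccccc3)ccc2=O)cc1`: 67.4%
Compound 3 `O=C(NC1CCCCC1)NS(=O)(=O)c1ccc(-n2nc(-c3ccccc3)ccc2=O)cc1`: 52.1%

In a functional assay on the whole organism (blood, strain Wistar albino) for inhibition, with Rattus norvegicus as the target, read by colorimetric assay, with stated times of 15 min and 90 min, at a dose of 20 mg/kg by the oral route (on this read-out higher numbers stand for more inhibition at the one dose given (going by the name of the read-out) and lower numbers for less inhibition), compound 1 gives the highest of these three numbers. Compound 2 stands a number 9.8 percentage points lower from compound 1 to compound 2 (within the scatter), while compound 3 stands a number 25.1 percentage points lower from compound 1 to compound 3 (beyond the scatter) and also a number 15.3 percentage points lower from compound 2 to compound 3 (beyond the scatter). Compound 4 `CCCNC(=O)NS(=O)(=O)c1ccc(-n2nc(-c3ccc(Cl)cc3)ccc2=O)cc1` keeps the propyl of compound 1 and differs from it in one place: chloro in place of hydrogen on an aromatic carbon. For the measured compounds named here, every measured step changes the group on the amide-type nitrogen, and none touches the aromatic ring where the chloro enters, so no measured step bears directly on this change. With nothing in the data arguing for a shift, the expected step of a number 2.2 percentage points lower from compound 1 to compound 4 (within the scatter) is none beyond the scatter. Compound 4 is therefore estimated at 75%, with a likely range from 55% to 90%.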

Compound 4, a percentage reported as inhibition, in the whole organism at one dose (the size of the read-out at that dose, not a potency): 74.3%
Compound 4: the middle estimate sits 0.7 percentage points above what was measured; low and high end bracket the measured number.
By their numbers in this assay, from the lowest: compound 3; then compounds 2, 4 and 1 (each within the scatter of the next).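

In this assay, the change from phenyl to 4-chlorophenyl gives a number 2.9 percentage points lower from compound 1 to compound 4 (within the scatter). The earlier compounds shown here varied only the group on the amide-type nitrogen, whereas this result shows that the far aromatic ring can carry a chloro, para to a large group, with no step beyond the scatter. No measurement shown gives a reason for this result. The compounds shown leave open whether a methoxy or an amine at this place would read the same, and whether chloro would behave alike with butyl or cyclohexyl on that nitrogen.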